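The compounds below may be only part of what the source reports. "The series", "measured", "known", "first", "only" and "open" are said of these compounds alone.

Two measured compounds share one core and differ only in the chlorine atoms on their saturated chains. Compound 1 `C[C@H]1CCCC[C@H](CCCC(Cl)Cl)c2c(O)cc(cc2O)[C@H](O)[C@@H](C)CCCC[C@H](CCCC(Cl)Cl)c2c(O)cc(cc2O)[C@@H]1O` carries chloro groups on both chains, and in a functional assay on HT-29 cells (Homo sapiens) for cytotoxicity (on this read-out lower numbers stand for an effect already at smaller amounts and higher numbers for an effect only at larger amounts of compound), compound 1 gives 2000 nM. Compound 2 `C[C@H]1CCCC[C@H](CCCCCl)c2c(O)cc(cc2O)[C@H](O)[C@@H](C)CCCC[C@H](CCCC(Cl)Cl)c2c(O)cc(cc2O)[C@@H]1O` has lost one of these chloro groups, and in this assay compound 2 gives 500 nM. Within the data shown here, compound 2 therefore stands at the lowest of the two numbers seen so far, and the step that separates it from its only neighbour is a 4.0-fold lower number from compound 1 to compound 2 (0.60 log units; beyond the scatter), which means compound 2 acts already at smaller amounts.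

Compound 3 `CCCC[C@H]1CCCC[C@H](C)[C@@H](O)c2cc(O)c(c(O)c2)[C@@H](CCCC(Cl)Cl)CCCC[C@H](C)[C@@H](O)c2cc(O)c1c(O)c2` continues along the same line: it differs from compound 2 by hydrogen in place of chloro on a saturated chain carbon, four bonds along the chain from a saturated ring carbon. Among the measured compounds shown here, the only measured step that bears on this change is a 4.0-fold lower number from compound 1 to compound 2 (0.60 log units; beyond the scatter), where a chloro group was likewise replaced by hydrogen on a saturated chain carbon. On that basis a step of similar direction, though possibly smaller, is expected for compound 3, namely a 2.0-fold lower number from compound 2 to compound 3 (0.30 log units; within the scatter). Compound 3 is thus expected to give about 250 nM in this assay, with a plausible range from 100 nM to 800 nM.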

Compound 3, half-maximal effective concentration: 1700 nM
Estimate against measurement, compound 3: 6.8-fold (0.83 log units) below; measured number outside the range, above it.
By their numbers in this assay, from the lowest: compound 2; then compounds 3 and 1 (each within the scatter of the next).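

In this assay, replacing chloro with hydrogen at this place, four bonds along the chain from a saturated ring carbon, does not repeat the earlier result: there is a 3.4-fold higher number from compound 2 to compound 3 (0.53 log units; beyond the scatter), the opposite direction to the step that came before it on the same chain. With all the chlorine gone from that chain end, there is a 1.2-fold lower number from compound 1 to compound 3 (0.07 log units; within the scatter), so the fully stripped chain and the chain with two chlorines cannot be told apart on this read-out, and only compound 2, with a single chlorine there, stands clear of both neighbours. Nothing at hand explains why the direction turns around.

The compounds shown leave open whether an amine, a hydroxyl or a fluorine on this carbon, or a longer chain, would keep the low number of compound 2 or return to the level of its two neighbours. They also leave open whether the same single chlorine would give a similar step on the second chain, which still carries its two chlorines in both compound 2 and compound 3.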